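Bromo to Methyl on the Phenyl Ring: Expected Maximal Response

The source may report more compounds than this note shows. Statements on the series, on what has been measured and on what is new or still open speak of the compounds shown alone.

Measured compounds:
Compound 1 `Cc1nc(N)sc1CCCN/C(N)=N/C(=O)NC(C)c1ccc(Br)cc1`: 0.87
Compound 2 `Cc1nc(N)sc1CCCN/C(N)=N/C(=S)N[C@H](C)c1ccccc1`: 0.87

In a functional assay on Right cardiac atrium for agonist activity at histamine H2 receptor (Cavia porcellus), with a stated time of 30 min, in the presence of a further agent that is not named here (a lower number here means a smaller maximal response, a higher number a larger maximal response), compound 1 gives 0.87, and compound 2 gives 0.87; the two stand level within the usual scatter. Compound 3 `Cc1ccc(C(C)NC(=O)/N=C(\N)NCCCc2sc(N)nc2C)cc1` differs from compound 1 in one place: methyl in place of bromo on an aromatic carbon. Within the data shown here, no measured step of this kind exists here, and both measured compounds reach much the same large response, so no change beyond the scatter is expected in this assay. Compound 3 is therefore expected to give 0.85, with a range from 0.7 to 0.98. The step expected is a number 0.020 lower from compound 1 to compound 3 (within the scatter), that is, essentially none.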

Compound 3, intrinsic activity: the largest response reached, as a fraction of the reference agonist's: 0.85
Estimate against measurement, compound 3: no gap at the digits printed, within the range that was stated.
By their numbers in this assay, from the lowest: compounds 3, 1 and 2 (each within the scatter of the next).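

In this assay, among these compounds, methyl in place of bromo gives a number 0.020 lower from compound 1 to compound 3 (within the scatter), so for the first time a single exchange at this position can be read directly. On this aromatic carbon, para to a large group, the large maximal response survives the swap of one heavy atom for another. Nothing in the data gives a reason for this result.

Still open, going by these compounds, is whether a quite different group on this carbon, such as an amine or a carboxylic acid, would keep the response. On these data alone, a longer chain there is equally open.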